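Fluoro Substitution on the Pendant Phenyl: Predicting Compound 4

The source may hold more compounds than are shown below. What is called first, only, known or untested is meant among the compounds shown, and "the series" means these compounds.

Measured compounds:
compound 1, `Cn1ccc2c(Oc3ccc(NC(=O)c4cc5cccnc5n(-c5ccccc5)c4=O)cc3F)ncnc21`: 63200 nM
compound 2, `Cn1ccc2c(Oc3ccc(NC(=O)c4cc5cccnc5n(-c5ccc(F)cc5)c4=O)cc3F)ncnc21`: 7320 nM
compound 3, `O=C(Nc1ccc(Oc2ncnc3[nH]ccc23)c(F)c1)c1cc2cccnc2n(-c2ccc(Br)cc2)c1=O`: 27300 nM

In a functional assay on A549 cells (Homo sapiens) for cytotoxicity, read by MTT assay, with a stated time of 72 h (on this read-out higher numbers stand for weaker inhibition and lower numbers for stronger inhibition), compound 1 gives 63200 nM and compound 2 gives 7320 nM. The change between them is fluoro in place of hydrogen on an aromatic carbon, and it made an 8.6-fold lower number from compound 1 to compound 2 (0.94 log units; beyond the scatter). Compound 3, `O=C(Nc1ccc(Oc2ncnc3[nH]ccc23)c(F)c1)c1cc2cccnc2n(-c2ccc(Br)cc2)c1=O`, gives 27300 nM; how its core differs from that of compound 1 is not broken down here. Compound 4, `O=C(Nc1ccc(Oc2ncnc3[nH]ccc23)c(F)c1)c1cc2cccnc2n(-c2ccc(Br)cc2F)c1=O`, is not yet measured. It differs from compound 3 by fluoro in place of hydrogen on an aromatic carbon, the same kind of change as that from compound 1 to compound 2, but at a different place: on an aromatic carbon ortho to a large group and meta to a bromo group rather than para to a large group. Resting on the step seen in compound 2, a smaller lowering is expected for compound 4, namely a 3.0-fold lower number from compound 3 to compound 4 (0.48 log units; beyond the scatter). The estimate for compound 4 is 9000 nM, expected between 3000 nM and 30000 nM.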

Compound 4, half-maximal inhibitory concentration: 218000 nM
Beside the measured number, compound 4's estimate is 24-fold (1.38 log units) below it; measured number outside the range, above it.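

In this assay, fluoro in place of hydrogen gave an 8.0-fold higher number from compound 3 to compound 4 (0.90 log units; beyond the scatter), whereas the same kind of change had lowered the number on the core of compound 1. The two steps run in opposite directions and do not agree: the same change on two cores in this assay, an 8.6-fold lower number (0.94 log units; beyond the scatter) from compound 1 to compound 2 and an 8.0-fold higher number (0.90 log units; beyond the scatter) from compound 3 to compound 4, 69-fold (1.84 log units) apart, beyond the scatter of two such steps This shows that the change does not carry over as a fixed step in this series, but it does not show which difference between the two pairs decides the outcome: the core, the place of the fluoro on the ring, or the bromo group.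

Open, on these data alone, is how a fluoro at the place it holds in compound 4 would act on the core of compound 1. Also open, as far as these compounds go, is how a chloro, a methoxy or an amine at that place would act on the core of compound 3.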